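The compounds below may be only part of what the source reports. "The series", "measured", "known", "first", "only" and "open" are said of these compounds alone.

In a functional assay on A2780 cells (Homo sapiens) for antiproliferative activity, read by resazurin assay, with a stated time of 72 h (a lower number here means a stronger inhibitor, a higher number a weaker inhibitor), compound 1 (`CN(Cc1ccccc1Br)C(=O)c1cc2c(Cc3ccccc3)n[nH]c2cc1O`) gives 1200 nM and compound 2 (`Cc1ccccc1CN(C)C(=O)c1cc2c(Cc3ccccc3)n[nH]c2cc1O`) gives 4400 nM while compound 3 (`CN(Cc1ccc(F)cc1)C(=O)c1cc2c(Cc3ccccc3)n[nH]c2cc1O`) gives 4100 nM on the same core. Compound 2 stands with compound 3 at the weak end of the three, with a 1.1-fold lower number from compound 2 to compound 3 (0.03 log units; within the scatter) between them. Compound 1 stands apart, through a 3.7-fold higher number from compound 1 to compound 2 (0.56 log units; beyond the scatter) and a 3.4-fold higher number from compound 1 to compound 3 (0.53 log units; beyond the scatter) as the steps beyond the scatter. The change to compound 4 (`CN(Cc1ccc(Br)cc1)C(=O)c1cc2c(Cc3ccccc3)n[nH]c2cc1O`) is 4-bromophenyl in place of 2-methylphenyl on a saturated chain carbon bound to an amide-type nitrogen, that is 2-methylbenzyl to 4-bromobenzyl. Its bromine is shared only with compound 1 at 1200 nM, though there as 2-bromophenyl, and the 4-fluorophenyl of compound 3 at 4100 nM sits level with compound 2. Only part of the step to compound 1 is therefore expected, toward a lower number and not clearly beyond the scatter, estimated as a 1.7-fold lower number from compound 2 to compound 4 (0.23 log units; within the scatter) in this assay overall. For compound 4 the expected value is 2600 nM with an estimated range from 1000 nM to 6000 nM in this measurement.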

Compound 4, half-maximal inhibitory concentration: 2800 nM
Compound 4: middle estimate off by 1.1-fold (0.03 log units), on the low side; the range from low to high includes it.
By their numbers in this assay, from the lowest: compound 1; then compounds 4, 3 and 2 (each within the scatter of the next).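

a 2.3-fold higher number from compound 1 to compound 4 (0.37 log units; beyond the scatter) separates the two bromine-bearing compounds, so in this assay the bromine alone does not bring the lower number of the 2-bromophenyl group. The 4-bromophenyl group instead sits level with the groups it was compared with, through a 1.6-fold lower number from compound 2 to compound 4 (0.20 log units; within the scatter) and a 1.5-fold lower number from compound 3 to compound 4 (0.17 log units; within the scatter) in the same assay. Nothing available here accounts for the gap between the two bromophenyl groups. Still open, from the compounds shown here alone, is whether chloro or iodo in place of the bromo of compound 1 would keep its number, and how an amine or a carboxylic acid on that ring would read.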